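The source may report more compounds than this note shows. Statements on the series, on what has been measured and on what is new or still open speak of the compounds shown alone.

Measured in a functional assay on cells (Cancer cell lines, Homo sapiens) for inhibition (on this read-out lower numbers stand for stronger inhibition of growth and higher numbers for weaker inhibition of growth), so far:
- compound 1 `Cc1cc(-c2nc3sc(C)cn3c2/C=N/NC(=N)N)c(C)s1` gives 18200 nM 
- compound 2 `Cc1cn2c(/C=N/NC(=N)N)c(-c3ccsc3)nc2s1` gives 19500 nM 
- compound 3 `N=C(N)N/N=C/c1c(-c2cccs2)nc2sccn12` gives 25700 nM 

Compound 3 at 25700 nM lies within the scatter of compound 1 and of compound 2, so no order can be read among the three values.

The next compound is compound 4 `Cc1cn2c(/C=N/NC(=N)N)c(-c3cccs3)nc2s1` with methyl in place of hydrogen on an aromatic carbon as its difference from compound 3, that is, methyl in place of hydrogen on an aromatic carbon of the shared core.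

Among the measured compounds shown here, the only measured step between compounds that differ in one place is a 1.1-fold higher number from compound 1 to compound 2 (0.03 log units; within the scatter) and it is small. It concerns thiophen-3-yl in place of 2,5-dimethylthiophen-3-yl, not the carbon changed here, so it bears on the new change only indirectly. For the measured compounds named here, no measured step tests this methyl alone. Compound 2 carries the same methyl, and its value of 19500 nM lies within the scatter of the value of compound 3, though the two compounds are not a single-place pair.

Nothing in the series therefore points to a real shift in this assay for this change. The expected step is a 1.3-fold lower number from compound 3 to compound 4 (0.11 log units; within the scatter) and it is not expected to exceed the scatter. For compound 4 the estimate is 20000 nM with an expected range from 11000 nM to 36000 nM in this read-out.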

Compound 4, concentration for total growth inhibition: 11700 nM
Estimate against measurement, compound 4: 1.7-fold (0.23 log units) above; the range from low to high includes it.
By their numbers in this assay, from the lowest: compounds 4, 1, 2 and 3 (each within the scatter of the next, the first and the last beyond it).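

Notes on the methyl position: In this assay the step for methyl in place of hydrogen, on the aromatic carbon next to the ring sulfur, is the first single-place change in the series to pass beyond the scatter (a 2.2-fold lower number from compound 3 to compound 4 (0.34 log units; beyond the scatter)), though it remains modest. Among the compounds carrying this same methyl, the changes to the thiophene substituent stay within the scatter (a 1.7-fold lower number from compound 2 to compound 4 (0.22 log units; within the scatter) and a 1.6-fold lower number from compound 1 to compound 4 (0.19 log units; within the scatter)), so in this small set the methyl on the shared core is the only single-place change with a readable effect, and no ranking of the thiophene groups can be drawn. No supporting data bear on why this methyl gives the step.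

On these data alone, only hydrogen and methyl appear at this carbon, so it stays open whether an ethyl, a longer chain, an amine or a carboxylic acid there would extend, hold or reverse the step. It also stays open whether the methyl step carries over to the thiophen-3-yl and 2,5-dimethylthiophen-3-yl compounds, for which no hydrogen partner appears among the compounds shown.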